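This account rests on a few compounds, and the source may have more. Where it says the series, first, only, none or still open, it means among the compounds named here.

For the measured compounds named here, in a physicochemical assay for solubility, in phosphate buffer, measured as kinetic solubility, with a stated time of 24 h, at pH 7.4 (a higher number here means a more soluble compound, a lower number a less soluble compound), compound 2 `CC(=O)N1CCN(c2ccc(CN(C3CC3)S(=O)(=O)Cc3ccccc3)cc2)CC1` gives 71000 nM, the only true number so far. Compound 1 `CC(=O)N1CCN(c2ccc(CN(C(C)C)S(=O)(=O)Cc3ccccc3)cc2)CC1` gives <= 1000 nM, which is a limit of the assay and not a number. Going by the values given here, the one measured step, an at least 71-fold higher number from compound 1 to compound 2 (1.85 log units; beyond the scatter), is large and involves a change on the same sulfonamide nitrogen. Compound 3 `CC(=O)N1CCN(c2ccc(CN(CCN(C)C)S(=O)(=O)Cc3ccccc3)cc2)CC1` changes that nitrogen again: 2-(dimethylamino)ethyl in place of cyclopropyl on a sulfonamide nitrogen. This is a different swap, with 2-(dimethylamino)ethyl in place of cyclopropyl, so that single step is only a loose guide. A small rise is expected, a 2.1-fold higher number from compound 2 to compound 3 (0.32 log units; beyond the scatter). Compound 3 is estimated at 150000 nM, within an expected range of 50000 nM to 400000 nM.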

Compound 3, solubility: 221000 nM
Estimate against measurement, compound 3: 1.5-fold (0.17 log units) below; the measured number falls inside the stated range.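

In this assay, a group with no ring on the sulfonamide nitrogen can still go with a higher number than cyclopropyl, a 3.1-fold higher number from compound 2 to compound 3 (0.49 log units; beyond the scatter). Against isopropyl, the same group gives an at least 220-fold higher number from compound 1 to compound 3 (2.34 log units; beyond the scatter). Compound 1 gives <= 1000 nM, which is a limit of the assay and not a number: the limit of <= 1000 nM in this assay, at which 1 of the 3 values shown sits.

From the compounds shown here alone, whether the higher number goes with the dimethylamino nitrogen or with the open chain itself remains open. A plain butyl chain or a chain ending in a carboxylic acid on the same nitrogen would help to separate the two.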